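Mirror-Image Endoperoxide and Its Expected Cytotoxicity

The compounds below may be only part of what the source reports. "The series", "measured", "known", "first", "only" and "open" are said of these compounds alone.

compound 1 `COC(=O)[C@@H](C)[C@@H]1CC[C@](C)(CCC(=O)C(C)(C)CCCC(C)=O)OO1`: 10 ug/mL
compound 2 `COC(=O)[C@@H](C)[C@@H]1CC[C@](C)(CCC2=C(C)C(=O)C[C@H]3C(C)(C)CCC[C@]23C)OO1`: < 3 ug/mL

In a functional assay on L5178Y cells (Mus musculus) for cytotoxicity, read by MTT assay (a higher number here means that more compound is needed for the effect, a lower number that less compound is needed), compound 1 gives 10 ug/mL. For compound 2 the result is only a limit, < 3 ug/mL, and so compound 2 stands at the limit of < 3 ug/mL in this assay, at which 1 of the 2 values shown sits. Compound 3 `COC(=O)[C@H](C)[C@H]1CC[C@@](C)(CCC2=C(C)C(=O)C[C@@H]3C(C)(C)CCC[C@@]23C)OO1` is the mirror image of compound 2: the two compounds have the same atoms and bonds and differ only in configuration as drawn: 5 of 5 stereo elements differ (all stereocentres are inverted: mirror images); a stereocentre at a saturated chain carbon is drawn S in compound 2 and R in compound 3; a stereocentre at a saturated ring carbon is drawn S in compound 2 and R in compound 3; a stereocentre at a saturated ring carbon is drawn S in compound 2 and R in compound 3; a stereocentre at a saturated ring carbon is drawn S in compound 2 and R in compound 3. For the measured compounds named here, no measured pair here shows what inverting every stereocentre does, so the step of an at least 1.6-fold higher number from compound 2 to compound 3 (0.22 log units; that floor lies within the scatter) is only an expectation, and some loss is expected for the mirror image. Compound 3 is expected to give 5 ug/mL, with a range from 1.5 ug/mL to 20 ug/mL.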

Compound 3, half-maximal effective concentration: 2 ug/mL
Estimate against measurement, compound 3: 2.5-fold (0.40 log units) above; the measured number falls inside the stated range.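

The value for compound 2, < 3 ug/mL, is a limit, so the step from compound 2 to compound 3 cannot be read. The compounds shown leave open whether inverting every stereocentre changes the result in this assay at all.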